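The compounds below may be only part of what the source reports. "The series", "measured", "known", "first", "only" and "open" are said of these compounds alone.

Compound 1 `COc1cnc(-n2cnc(N3CCN(C)CC3)n2)c2[nH]cc(C(=O)C(=O)N3CCN(C(=O)c4ccccc4)CC3)c12` in a functional assay on MT2 cells (Homo sapiens) for cytotoxicity, read by XTT assay, with a stated time of 3 days (a lower number here means that less compound is tolerated, a higher number that more compound is tolerated), gives > 300000 nM, which is a limit of the assay rather than a number.

Compound 2 `COc1cnc(-n2cnc(C(=O)N(C)C)n2)c2[nH]cc(C(=O)C(=O)N3CCN(C(=O)c4ccccc4)CC3)c12` in this assay gives > 300000 nM, again a limit and not a number.

Among the compounds with values here, both values sit at the same limit (the limit of > 300000 nM in this assay, at which 2 of the 2 values shown sit), so the only measured step, a step that the two limits leave unreadable from compound 1 to compound 2, cannot be read and its size is unknown. Compound 2 thus stands at that limit, and nothing in these numbers separates it from compound 1. The unmeasured compound 3 `COc1cnc(-n2cnc(C(=O)N3CCN(C)CC3)n2)c2[nH]cc(C(=O)C(=O)N3CCN(C(=O)c4ccccc4)CC3)c12` differs from compound 2 by 4-methylpiperazin-1-yl in place of dimethylamino on a carbonyl carbon. Within the data shown here, no measured step bears on this change: the single recorded step is unreadable, and no other pair is available. Compound 3 is therefore expected to remain at the limit, with an expected step that the limit leaves unreadable from compound 2 to compound 3 that does not go beyond the scatter. The estimate for compound 3 in this assay is 400000 nM, ranging from 200000 nM to 1000000 nM.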

Compound 3, half-maximal cytotoxic concentration: > 150000 nM
Compound 3 ended at the assay's limit; the forecaster's own chance of this, stated with the estimate: 85%; the middle value does not contradict the limit.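

In this assay compound 3 gives > 150000 nM, which is a limit and not a number. Within the data shown here, no step among compound 1, compound 2 and compound 3 can be read. The compounds shown leave open at what concentration any of them would become cytotoxic, and whether they differ at all.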